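Working notes: from 3,4-dichlorophenyl to phenyl

A few compounds are considered here, and "the series" means these few. Any claim that something is new, unique, unknown or untested is made for them only; others in the source may bear on it.

Measured in a functional assay on MCF7 cells (Homo sapiens) for antiproliferative activity, read by MTT assay, with a stated time of 24 h (on this read-out higher numbers stand for weaker inhibition of growth and lower numbers for stronger inhibition of growth), so far:
- compound 1 `NC(=S)N1N=C(c2ccc(Br)cc2)CC1c1ccc2ccccc2c1` gives 440 nM here
- compound 2 `NC(=S)N1N=C(c2ccc(Cl)c(Cl)c2)CC1c1ccc2ccccc2c1` gives 350 nM here

Compound 2 at 350 nM and compound 1 at 440 nM lie within the scatter of each other, so compound 2 holds no distinct place on these two numbers.

Next comes compound 3 `NC(=S)N1N=C(c2ccccc2)CC1c1ccc2ccccc2c1`, with the change phenyl in place of 3,4-dichlorophenyl on a carbon with a double bond to nitrogen in the form of phenyl in place of 3,4-dichlorophenyl on a carbon with a double bond to nitrogen. Among the compounds with values here, the only measured step is a 1.3-fold lower number from compound 1 to compound 2 (0.10 log units; within the scatter) and it swaps 4-bromophenyl for 3,4-dichlorophenyl at this same place. Within the data shown here, no measured compound carries phenyl here, so that step is only a loose guide. In this assay, among the measured compounds shown here, no step clearly beyond the scatter is expected, with some lean toward a higher number. The estimated step is a 1.6-fold higher number from compound 2 to compound 3 (0.20 log units; within the scatter) and remains a rough expectation. For compound 3 the expected value is 550 nM with an estimated range from 220 nM to 1500 nM on this read-out.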

Compound 3, concentration for 50% growth inhibition: 13800 nM
Beside the measured number, compound 3's estimate is 25-fold (1.40 log units) below it; the whole stated range lies below it.
By their numbers in this assay, from the lowest: compounds 2 and 1 (each within the scatter of the next); then compound 3.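

In this assay this position proves far from indifferent: taking both chlorines off 3,4-dichlorophenyl gives a 39-fold higher number from compound 2 to compound 3 (1.60 log units; beyond the scatter) and weakens growth inhibition sharply. Hydrogen in place of bromo tells the same story, with a 31-fold higher number from compound 1 to compound 3 (1.50 log units; beyond the scatter). Compound 1 and compound 2 stay within the scatter of each other, so among these three compounds the clear divide lies between a halogen-bearing phenyl and plain phenyl, and none of the three goes against it. No measured evidence on the reason for this divide is at hand.

The compounds shown do not tell whether the gain depends on halogen as such, since no other kind of group on this phenyl appears among them. From the compounds shown here alone, whether methoxy, nitrile or an amine would match bromo or the two chlorines, or stay with plain phenyl, remains open.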